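Compound 4: cyclohexylmethyl in place of 4-cyanobenzyl

This account rests on a few compounds, and the source may have more. Where it says the series, first, only, none or still open, it means among the compounds named here.

Of the compounds shown here, three sharing one core have been tested in an ADME assay on RAW264.7 cells (Mus musculus) for cytotoxicity, read by MTT assay, with a stated time of 24 h, in the presence of a further agent that is not named here; a higher number here means a weaker inhibitor, a lower number a stronger inhibitor. Compound 1 is `CCOc1ccc(C(O)C2OC(=O)c3c(OC)cc(OC)cc32)cc1`, and compound 2 is `CCC(C)Oc1ccc(C(O)C2OC(=O)c3c(OC)cc(OC)cc32)cc1`. Compound 3 is `COc1cc(OC)c2c(c1)C(C(O)c1ccc(OCc3ccc(C#N)cc3)cc1)OC2=O`.

In this assay compound 1 gives > 40000 nM, which is a limit and not a number. Compound 2 gives > 40000 nM, again a limit. Compound 3 gives > 40000 nM, also a limit. Compound 3 therefore stands with the other two, and the whole set sits at the limit of > 40000 nM in this assay, at which 3 of the 3 values shown sit.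

Compound 4, `COc1cc(OC)c2c(c1)C(C(O)c1ccc(OCC3CCCCC3)cc1)OC2=O`, has not yet been measured. It differs from compound 3 by cyclohexyl in place of 4-cyanophenyl on a saturated chain carbon bound to an oxygen on an aromatic ring. In short, cyclohexyl stands in place of 4-cyanophenyl on a saturated chain carbon bound to an oxygen on an aromatic ring.

Three measured steps change the group at this same end of the molecule: a step that the two limits leave unreadable from compound 1 to compound 2, a step that the two limits leave unreadable from compound 1 to compound 3 and a step that the two limits leave unreadable from compound 2 to compound 3. None of them has a readable size, so they point in no direction. They do show that ethyl, sec-butyl and 4-cyanobenzyl groups all leave the result at the limit. No step beyond the scatter is expected in this assay, and compound 4 will most likely report only a limit as well. The expected step is a step that the limit leaves unreadable from compound 3 to compound 4. For compound 4 the estimated value is 45000 nM, with an expected range from 22000 nM to 90000 nM.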

Compound 4, half-maximal inhibitory concentration: > 40000 nM
Compound 4: no number, only a limit; the forecaster's own chance of this, stated with the estimate: 85%; the middle value lies beyond the limit too.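

In this assay compound 4 gives > 40000 nM as a limit and not a number, and its steps from compound 1, compound 2 and compound 3 cannot be read. How far past that limit any of the four compounds lies stays open, as does whether any other group here would give a readable value, because all of them sit together: the limit of > 40000 nM in this assay, at which 4 of the 4 values shown sit.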